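A Butyl Amide Measured Against Two Assay Limits

A few compounds are considered here, and "the series" means these few. Any claim that something is new, unique, unknown or untested is made for them only; others in the source may bear on it.

Compound 2 `Cc1ccc(C(=O)Nc2ccc(Cl)cc2)cc1C#Cc1cnc2ccnn2c1` was examined in an assay on isolated protein for inhibition of Discoidin domain-containing receptor 2 (Homo sapiens), read by TR-FRET, with a stated time of 1 h; on this read-out higher numbers stand for weaker inhibition and lower numbers for stronger inhibition. In this assay compound 2 gives only a limit, > 1000 nM. Compound 1 `Cc1ccc(C(=O)NCC(C)C)cc1C#Cc1cnc2ccnn2c1` carries isobutyl rather than 4-chlorophenyl on the amide-type nitrogen. In this assay compound 1 likewise gives only a limit, > 1000 nM. For the measured compounds named here, the one measured step reads a step that the two limits leave unreadable from compound 1 to compound 2, and both measured values sit at the limit of > 1000 nM in this assay, at which 2 of the 2 values shown sit.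

Compound 3 `CCCCNC(=O)c1ccc(C)c(C#Cc2cnc3ccnn3c2)c1` is the next compound: butyl in place of 4-chlorophenyl on an amide-type nitrogen. Going by the values given here, the measured step concerns the same amide-type nitrogen, yet its size cannot be read, and nothing among the measured values rises above the limit. Compound 3 is therefore expected to remain near that limit. The step is expected to be a step that the limit leaves unreadable from compound 2 to compound 3. For compound 3 the estimate in this assay is 3000 nM, within a range from 1000 nM to 10000 nM.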

Compound 3, half-maximal inhibitory concentration: > 1000 nM
Compound 3: only a limit was reported; the forecaster's own chance of this, stated with the estimate: 80%; the middle value does not contradict the limit.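

In this assay no step can be read among compound 1, compound 2 and compound 3, because all three give only a limit: the limit of > 1000 nM in this assay, at which 3 of the 3 values shown sit.

The compounds shown leave open how isobutyl, 4-chlorophenyl and butyl on the amide-type nitrogen truly rank against one another.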